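The source may report more compounds than this note shows. Statements on the series, on what has been measured and on what is new or still open speak of the compounds shown alone.

Compound 1 `Cc1c(Cn2ccnc2)n(CCNS(=O)(=O)c2ccc(F)cc2)c2ccc(C(=O)O)cc12` was tested in an assay with Thromboxane-A synthase (Homo sapiens) as the target, using microsomes (a higher number here means a weaker inhibitor, a lower number a stronger inhibitor), and gives 20 nM. Compound 2 `Cc1c(Cn2ccnc2)n(CCCCNS(=O)(=O)c2ccc(F)cc2)c2ccc(C(=O)O)cc12`, which was tested in the same way, gives 39 nM in this assay. The gap between these two numbers lies within the scatter of repeated measurements, so the two compounds cannot be separated on this evidence. Compound 1 therefore stands at the lowest of the two numbers recorded, but not apart from compound 2.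

Compound 3 `Cc1c(Cn2ccnc2)n(CCNS(=O)(=O)c2ccc(F)cc2)c2ccc(CCC(=O)O)cc12` has not yet been measured. It differs from compound 1 in one place: 2-carboxyethyl in place of carboxy on an aromatic carbon. Among the compounds with values here, no measured pair shows this particular change, so any expectation rests on the change alone. Compound 3 is expected to give 40 nM in this assay, with a range from 10 nM to 160 nM. The step of a 2.0-fold higher number from compound 1 to compound 3 (0.30 log units; within the scatter) that this estimate implies is expected to be a modest weakening, possibly no larger than the scatter.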

Compound 3, half-maximal inhibitory concentration: 135 nM
Estimate against measurement, compound 3: 3.4-fold (0.53 log units) below; measured number inside the range.
By their numbers in this assay, from the lowest: compounds 1 and 2 (each within the scatter of the next); then compound 3.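

Compounds 1 and 2 both carry carboxy on this aromatic carbon, so they could not show whether this position tolerates change. Compound 3 now gives the first reading: in this assay, replacing carboxy with 2-carboxyethyl gives a 6.8-fold higher number from compound 1 to compound 3 (0.83 log units; beyond the scatter), so this position is sensitive to the change and the longer group gives a weaker inhibitor than carboxy in this one pair. No measurement shown here accounts for this loss, so the result records its size but not its cause.

Open, from the compounds shown here alone, is how the number would respond to carboxymethyl, a chain of intermediate length, or to a group that replaces the carboxylic acid, such as a methyl ester or a primary amide. Also open, going by these compounds, is whether 2-carboxyethyl would produce a similar step on the longer side chain of compound 2.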